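Carbamoyl to benzoyl on a thioxo-piperazine furoyl series

A few compounds are considered here, and "the series" means these few. Any claim that something is new, unique, unknown or untested is made for them only; others in the source may bear on it.

Measured compounds:
compound 1 `N#C/C(=C\N1CCN(C(=O)c2ccco2)C1=S)C(N)=O`: 9300 nM
compound 2 `COc1cc(C(=O)N2CCN(C=O)C2=S)cc(OC)c1OC`: 20700 nM

In a functional assay on T47D cells (Homo sapiens) for inhibition, read by sulforhodamine B assay, with a stated time of 48 h (a lower number here means a stronger inhibitor of growth, a higher number a weaker inhibitor of growth), compound 1 gives 9300 nM, the lowest number of the two. Compound 2 gives 20700 nM in this assay, a higher number, beyond the scatter. Compound 3 `N#C/C(=C\N1CCN(C(=O)c2ccco2)C1=S)C(=O)c1ccccc1` differs from compound 1 by phenyl in place of amino on a carbonyl carbon, carbamoyl to benzoyl. Among the compounds with values here, no measured pair shows this change, so the size of the step is open; a modest move toward a lower number, possibly within the scatter, is expected, giving a 1.6-fold lower number from compound 1 to compound 3 (0.19 log units; within the scatter). Compound 3 is therefore estimated at 6000 nM, within a range from 1500 nM to 25000 nM.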

Compound 3, concentration for 50% growth inhibition: 7200 nM
The estimate for compound 3 lay 1.2-fold (0.08 log units) below the measured number; low and high end bracket the measured number.
By their numbers in this assay, from the lowest: compounds 3 and 1 (each within the scatter of the next); then compound 2.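

In this assay the exchange of carbamoyl for benzoyl gives a 1.3-fold lower number from compound 1 to compound 3 (0.11 log units; within the scatter) and so leaves the two compounds indistinguishable. On this carbonyl carbon, then, a single amino group and a whole phenyl ring, which brings a six-membered aromatic ring and removes a hydrogen-bond donor, are both accommodated with no change that can be read. The data offer no explanation for this result. Still open, as far as these compounds go, is how a methyl group, a dimethylamino group or a substituted phenyl ring at this place would read, and whether any group there moves the number beyond the scatter.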